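The compounds below may be only part of what the source reports. "The series", "measured", "known", "first", "only" and "open" are said of these compounds alone.

Three compounds with one shared core and a varying aryl group on the ring nitrogen have been tested in a functional assay on NCI-H1975 cells (Homo sapiens) for antiproliferative activity, read by MTT assay, with a stated time of 72 h; on this read-out lower numbers stand for stronger inhibition and higher numbers for weaker inhibition. Compound 1 `COc1cc2ncnc(Nc3ccc(F)c(Cl)c3)c2cc1OCCCCC(=O)Nc1ccc(S(N)(=O)=O)cc1` gives 35600 nM, compound 2 `COc1cc2ncnc(Nc3cccc(Cl)c3)c2cc1OCCCCC(=O)Nc1ccc(S(N)(=O)=O)cc1` gives 33200 nM, and compound 3 `COc1cc2ncnc(Nc3cc(F)c(F)c(F)c3)c2cc1OCCCCC(=O)Nc1ccc(S(N)(=O)=O)cc1` gives 20000 nM. All three numbers lie within the scatter of one another, with compound 3 at the low end: a 1.8-fold lower number from compound 1 to compound 3 (0.25 log units; within the scatter) and a 1.7-fold lower number from compound 2 to compound 3 (0.22 log units; within the scatter).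

Compound 4 `CCc1ccc(Nc2ncnc3cc(OC)c(OCCCCC(=O)Nc4ccc(S(N)(=O)=O)cc4)cc23)cc1` differs from compound 3 in one place: 4-ethylphenyl in place of 3,4,5-trifluorophenyl on a nitrogen on an aromatic ring. For the measured compounds named here, the earlier changes swapped one halogenated aryl group for another and left the numbers essentially unchanged; none of them put a halogen-free aryl group in this position, so no measured step bears directly on this swap. Compound 4 is therefore expected to stay close to compound 3, with a 1.3-fold higher number from compound 3 to compound 4 (0.10 log units; within the scatter), and its estimated value is 25000 nM, likely between 8000 nM and 80000 nM.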

Compound 4, half-maximal inhibitory concentration: 10300 nM
Beside the measured number, compound 4's estimate is 2.4-fold (0.39 log units) above it; measured number inside the range.
By their numbers in this assay, from the lowest: compounds 4, 3, 2 and 1 (each within the scatter of the next, the first and the last beyond it).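

In this assay, for the compounds shown here, a halogen-free aryl group on this nitrogen holds up: 4-ethylphenyl gives a 3.2-fold lower number from compound 2 to compound 4 (0.51 log units; beyond the scatter) and a 3.5-fold lower number from compound 1 to compound 4 (0.54 log units; beyond the scatter) as the first steps beyond the scatter in this set, both modest, whereas a 1.9-fold lower number from compound 3 to compound 4 (0.29 log units; within the scatter) stays within it. No halogen on this aryl ring is therefore required for the numbers seen, and the separation holds only against the two chlorine-bearing groups. Nothing on hand explains the shift. Still open, on these data alone, is whether the ethyl group itself matters, which 4-methylphenyl or 4-propylphenyl would test, and whether an amine such as 4-aminophenyl behaves alike on this nitrogen.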